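Plasma protein binding: 1H-pyrazol-1-yl in place of pyrimidin-2-yl

A few compounds are considered here, and "the series" means these few. Any claim that something is new, unique, unknown or untested is made for them only; others in the source may bear on it.

Values measured in an ADME assay on a cell-free system (plasma, Mus musculus) for protein binding, read by LC-MS, using ultracentrifugation, with a stated time of 4.2 h, tested at 1000 ng/mL, are as follows.
- Compound 1 `O=C(NNS(=O)(=O)c1ccccc1F)c1cc(F)cc(-n2cccn2)c1` gives 98.9% here.
- Compound 2 `C=CCOc1ccc(F)c(C(=O)NNS(=O)(=O)c2ccccc2)c1` gives 98% here.
- Compound 3 `Cc1cc(-c2ncccn2)cc(C(=O)NNS(=O)(=O)c2ccccc2)c1F` gives 99.4% here.

Compound 3 sits at the tightly bound end of this small set. Its unbound fraction lies within the scatter of compound 1 and beyond the scatter of compound 2, which has the higher unbound fraction. Compound 4 `Cc1cc(-n2cccn2)cc(C(=O)NNS(=O)(=O)c2ccccc2)c1F` is not yet measured. It differs from compound 3 by 1H-pyrazol-1-yl in place of pyrimidin-2-yl on an aromatic carbon and has 1H-pyrazol-1-yl in place of pyrimidin-2-yl on an aromatic carbon. For the measured compounds named here, no measured pair isolates this change. Compound 1 also carries 1H-pyrazol-1-yl and gives 98.9% despite other differences in structure, so a change beyond the scatter is not expected. The expected step a 1.3-fold higher unbound fraction from compound 3 to compound 4 (0.12 log units; within the scatter) is a small rise in unbound fraction, within the scatter. In this assay compound 4 is estimated at 99.2% with an expected range from 98.4% to 99.6% in this read-out.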

Compound 4, plasma protein binding in the Mus musculus assay: 99.2%
Estimate against measurement, compound 4: no gap at the digits printed; measured number inside the range.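

In the Mus musculus assay, the first pair isolating this position gives a 1.3-fold higher unbound fraction from compound 3 to compound 4 (0.12 log units; within the scatter), so 1H-pyrazol-1-yl in place of pyrimidin-2-yl leaves plasma protein binding within the scatter. The earlier compounds shown here could not show this, as none of them formed a pair differing only at this aromatic carbon. In a physicochemical assay for solubility, read by nephelometry, in phosphate buffer, measured as kinetic solubility, at pH 6.5 (on this read-out lower numbers stand for lower solubility and higher numbers for higher solubility), compound 3 gives 50 ug/mL and compound 4 gives 6.3 ug/mL in this read-out. The same change does separate the two compounds in the physicochemical assay, so for this pair it lowers solubility with no free-fraction shift beyond the scatter: the measured solubility of compound 3, 50 ug/mL, and of compound 4, 6.3 ug/mL, a 7.9-fold lower number (0.90 log units; beyond the scatter)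

On these data alone, this is a single pair on a single core; whether both outcomes carry over to other cores remains open. Also open, as far as these compounds go, is how an amine or a carboxylic acid on this aromatic carbon would read in the Mus musculus assay and in the physicochemical assay.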